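Benzyl on the amide-type nitrogen: expected step

The source may hold more compounds than are shown below. What is called first, only, known or untested is meant among the compounds shown, and "the series" means these compounds.

For the measured compounds named here, in a functional assay on U-937 cells (Homo sapiens), read by cAMP accumulation (a lower number here means that less compound is needed, a higher number that more compound is needed for the effect), compound 2 `CCc1nn(C2CCCC2)c2c1CCN(c1ccsc1)C2=O` gives 36 nM, the lower of the two numbers so far, and compound 1 `CCc1nn(C2CCCC2)c2c1CCN(c1cccc(OC)c1)C2=O` gives 330 nM. Compound 3 `CCc1nn(C2CCCC2)c2c1CCN(Cc1ccccc1)C2=O` carries benzyl in place of thiophen-3-yl on an amide-type nitrogen in a ring. Going by the values given here, the only measured step at this place is a 9.2-fold lower number from compound 1 to compound 2 (0.96 log units; beyond the scatter), which lies beyond the scatter. Among the compounds with values here, no benzyl analogue has been measured, so that step gives only a rough size. A higher number of somewhat smaller size is expected, with a 5.0-fold higher number from compound 2 to compound 3 (0.70 log units; beyond the scatter) as the estimated step. For compound 3 the estimated value is 180 nM, with an expected range of 50 nM to 650 nM.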

Compound 3, half-maximal effective concentration: 36 nM
For compound 3 the middle estimate is 5.0-fold (0.70 log units) above the measured one; the whole stated range lies above it.
By their numbers in this assay, from the lowest: compounds 2 and 3 (each within the scatter of the next); then compound 1.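

In this assay, benzyl in place of thiophen-3-yl on the amide-type nitrogen in a ring leaves the number unchanged (no change at the digits printed from compound 2 to compound 3 (within the scatter)), so this position accepts either group. Benzyl in place of 3-methoxyphenyl gives the larger step (a 9.2-fold lower number from compound 1 to compound 3 (0.96 log units; beyond the scatter)), so the number of compound 1 does not extend to every group carrying a six-membered aromatic ring of carbon only. No supporting evidence explains either step.

On these data alone, whether a 3-methoxy group on the benzyl keeps the number of compound 3 remains open. So does the effect of a longer chain, such as 2-phenylethyl, or of a carboxylic acid on the ring.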